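A Methyl Link on the Ring Nitrogen

The source may hold more compounds than are shown below. What is called first, only, known or untested is meant among the compounds shown, and "the series" means these compounds.

In a toxicity assay on HEK293 cells (Homo sapiens) for cytotoxicity, read by luminescence, with a stated time of 24 h (on this read-out higher numbers stand for weaker inhibition and lower numbers for stronger inhibition), compound 1 (`Cc1cccc2sc(NC(=O)CCN3CCN(CC4CCCO4)CC3)nc12`) gives 46300 nM and compound 2 (`Cc1cccc2sc(NC(=O)CCN3CCN(C4CCCCC4)CC3)nc12`) gives 47100 nM as its reading. These two numbers are all that has been measured so far, and they stand level with each other. The step that connects them, a 1.0-fold higher number from compound 1 to compound 2 (0.01 log units; within the scatter), swaps (oxolan-2-yl)methyl for cyclohexyl on an amine nitrogen in a ring.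

Compound 3 (`Cc1cccc2sc(NC(=O)CCN3CCN(CC4CCCCC4)CC3)nc12`) changes that same nitrogen again, with cyclohexylmethyl in place of cyclohexyl (cyclohexylmethyl in place of cyclohexyl on an amine nitrogen in a ring). It pairs the carbon-only ring of compound 2 with the methyl link already present in compound 1.

Going by the values given here, the measured step at this nitrogen is the only guide, and a single step is thin evidence. Compound 2 differs from compound 1 by no more than the scatter, as a 1.0-fold higher number from compound 1 to compound 2 (0.01 log units; within the scatter) shows, so no clear shift is expected in this assay here either. The expected change is a 1.1-fold lower number from compound 2 to compound 3 (0.05 log units; within the scatter), which would not be a real difference. For compound 3 the estimate is 42000 nM, with an expected range from 20000 nM to 80000 nM on this reading.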

Compound 3, half-maximal inhibitory concentration: 30700 nM
Compound 3: the middle estimate sits 1.4-fold (0.14 log units) above what was measured; measured number inside the range.
By their numbers in this assay, from the lowest: compounds 3, 1 and 2 (each within the scatter of the next).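

Putting a methyl link between the ring nitrogen and the cyclohexyl group (a 1.5-fold lower number from compound 2 to compound 3 (0.19 log units; within the scatter)) stays within the usual scatter of this assay, so at this position the carbon-only ring gives no real difference whether it sits directly on the nitrogen or one carbon further out. The second step (a 1.5-fold lower number from compound 1 to compound 3 (0.18 log units; within the scatter)) keeps the methyl link in place and changes only the ring at its end, with cyclohexyl in place of oxolan-2-yl, and this too stays within the scatter, so the two rings cannot be told apart on this read-out. Nothing available explains why these readings stay level.

The compounds shown leave open whether any group on this nitrogen can move the reading beyond the scatter, for instance a phenyl ring, a longer chain such as cyclohexylethyl, or a carboxylic acid on the cyclohexyl ring. As far as these compounds go, they also leave the shared core untested, since it stays the same throughout, so the role of its methyl group or its amide hydrogen in this reading remains unknown.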